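Swapping a saturated ring for a fluorinated aromatic one

The compounds below may be only part of what the source reports. "The series", "measured", "known", "first", "only" and "open" are said of these compounds alone.

In an assay on HEK293 cells for positive allosteric modulation of metabotropic glutamate receptor 5 (Homo sapiens), read by FLIPR (on this read-out higher numbers stand for an effect only at larger amounts of compound and lower numbers for an effect already at smaller amounts), compound 2 `CC1CCCC(C(=O)N2CC(c3nc(-c4cccc(Cl)c4)no3)C2)C1` gives 410 nM, the lowest of the three numbers recorded so far. Compound 1 `O=C(c1ccc(Cl)cc1)N1CC(c2nc(-c3cccc(F)c3)no2)C1` gives 2500 nM and compound 3 `O=C(c1ccc(F)c(F)c1)N1CC(c2nc(-c3cccc(F)c3)no2)C1` gives 3200 nM in this assay; both carry an aromatic group on the carbonyl carbon where compound 2 carries 3-methylcyclohexyl, and both carry a fluorine on the other aromatic ring where compound 2 carries chlorine. Going by the values given here, the only step measured within one change, a 1.3-fold higher number from compound 1 to compound 3 (0.11 log units; within the scatter), compares two aromatic amide groups and so does not speak to the change at hand. Compound 4 `O=C(c1ccc(F)cc1)N1CC(c2nc(-c3cccc(Cl)c3)no2)C1` differs from compound 2 by 4-fluorophenyl in place of 3-methylcyclohexyl on a carbonyl carbon. Among the compounds with values here, no single measured step isolates this swap; compounds 1 and 3 show only that the aromatic amides present here sit at higher numbers than compound 2 while also differing elsewhere. The expected step from compound 2 to compound 4 in this assay is therefore a 4.4-fold higher number from compound 2 to compound 4 (0.64 log units; beyond the scatter), towards a higher number. Compound 4 is expected to give about 1800 nM in this assay, estimated between 600 nM and 5000 nM.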

Compound 4, half-maximal effective concentration: > 10000 nM
Compound 4: a limit, no number; the forecaster's own chance of this, stated with the estimate: 5%; middle value at least 5.5-fold (0.74 log units) from the limit.
By their numbers in this assay, from the lowest: compound 2; then compounds 1 and 3 (each within the scatter of the next). At a limit, above all of these: compound 4.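

On a carbonyl carbon whose other neighbours are an amide-type nitrogen in a ring, the swap of 3-methylcyclohexyl for 4-fluorophenyl can now be read directly, with nothing else changing: in this assay it gives an at least 24-fold higher number from compound 2 to compound 4 (1.38 log units; beyond the scatter). The two groups match in their count of heavy atoms and in having no hydrogen-bond donors or acceptors, and still the read-out separates them clearly. Compound 4 stands at a limit of the assay and not at a number, so the full size of the step stays unknown: the limit of > 10000 nM in this assay, at which 1 of the 4 values shown sits.

The compounds shown leave open whether the ring's aromatic nature or its fluorine goes with the step, which a plain phenyl on this carbonyl carbon would help to separate. Also open, on these data alone, is whether a plain cyclohexyl, without the methyl, or a longer open carbon chain would keep a number close to that of compound 2.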